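Pyridine in Place of Fluorophenyl on an Insoluble Acid

The source may report more compounds than this note shows. Statements on the series, on what has been measured and on what is new or still open speak of the compounds shown alone.

Compound 3, `CCCOc1ccc(C[C@@H](Cc2ccccc2)C(=O)O)cc1CNC(=O)c1ccc(-c2ccccc2F)cc1`, is the starting point. In a physicochemical assay for solubility, read by HPLC, in phosphate buffer, measured as thermodynamic solubility, with a stated time of 48 h, at pH 7.2 (a lower number here means a less soluble compound, a higher number a more soluble compound), compound 3 gives < 1 ug/mL, which is a limit of the assay and not a number. Its two measured neighbours are compound 1, `CCCOc1ccc(C[C@@H](Cc2ccccc2)C(=O)O)cc1CNC(=O)c1ccc(-c2ccccc2C)cc1`, and compound 2, `CCCOc1ccc(C[C@@H](Cc2ccccc2)C(=O)O)cc1CNC(=O)c1ccc(-c2ccc(F)cc2)cc1`. In this assay compound 1 gives < 1 ug/mL, a limit. In this assay compound 2 gives < 1 ug/mL, also a limit. Because every value shown sits at the limit of < 1 ug/mL in this assay, at which 3 of the 3 values shown sit, the steps a step that the two limits leave unreadable from compound 1 to compound 2, a step that the two limits leave unreadable from compound 1 to compound 3 and a step that the two limits leave unreadable from compound 2 to compound 3 have no readable size or direction.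

Compound 4, `CCCOc1ccc(C[C@@H](Cc2ccccc2)C(=O)O)cc1CNC(=O)c1ccc(-c2cccnc2)cc1`, differs from compound 3 in one place: pyridin-3-yl in place of 2-fluorophenyl on an aromatic carbon. For the measured compounds named here, no measured step shows what such a swap does in this assay, so the expectation rests on the structural change alone and stays close to the limit. Compound 4 is expected at 2 ug/mL, within a range of 0.5 ug/mL to 10 ug/mL. The expected step is an at least 2.0-fold higher number from compound 3 to compound 4 (0.30 log units; that floor lies within the scatter), which may not rise clearly beyond the scatter.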

Compound 4, solubility: 69.5 ug/mL
For compound 4 the middle estimate is 35-fold (1.54 log units) below the measured one; the measured number lies above the stated range.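

At this position, on an aromatic carbon para to a large group, the swaps among compound 1, compound 2 and compound 3 cannot be read, but pyridin-3-yl gives the first number above the limit in this assay. In place of 2-fluorophenyl it gives an at least 69-fold higher number from compound 3 to compound 4 (1.84 log units; beyond the scatter), in place of 4-fluorophenyl an at least 69-fold higher number from compound 2 to compound 4 (1.84 log units; beyond the scatter), and in place of 2-methylphenyl an at least 69-fold higher number from compound 1 to compound 4 (1.84 log units; beyond the scatter). These steps give only a lowest size, because each starting compound sits at a limit and not at a number: the limit of < 1 ug/mL in this assay, at which 3 of the 4 values shown sit.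

As far as these compounds go, the full size of each step stays open. So does whether pyridin-2-yl, pyridin-4-yl or a phenyl ring carrying an amine would give a similar number at this position.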